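Carboxy in place of trifluoromethoxy on an aromatic carbon

A few compounds are considered here, and "the series" means these few. Any claim that something is new, unique, unknown or untested is made for them only; others in the source may bear on it.

In a physicochemical assay for solubility, read by HPLC, using the shake flask method, in phosphate buffer, with a stated time of 20 h, at pH 6.5 (on this read-out higher numbers stand for higher solubility and lower numbers for lower solubility), compound 1 (`NC1CCN(c2nccc3[nH]c(-c4cccc(OC(F)(F)F)c4)nc23)CC1`) gives 200000 nM, compound 2 (`CN(C)C1CCN(c2nccc3[nH]c(-c4cccc(OC(F)(F)F)c4)nc23)CC1`) gives 180000 nM and compound 3 (`CN1CCN(CC2CCN(c3nccc4[nH]c(-c5cccc(OC(F)(F)F)c5)nc34)CC2)CC1`) gives 200000 nM. Compound 3 stands level with compound 1 at the digits shown and within the scatter of compound 2.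

Compound 4 (`CN1CCN(CC2CCN(c3nccc4[nH]c(-c5cccc(C(=O)O)c5)nc34)CC2)CC1`) keeps the (4-methylpiperazin-1-yl)methyl group of compound 3 and carries carboxy in place of trifluoromethoxy on an aromatic carbon.

The measured steps are a 1.1-fold lower number from compound 1 to compound 2 (0.05 log units; within the scatter), no change at the digits printed from compound 1 to compound 3 (within the scatter) and a 1.1-fold higher number from compound 2 to compound 3 (0.05 log units; within the scatter). All three lie within the scatter, and all three fall on a saturated ring carbon. None replaces trifluoromethoxy, so the series gives no direct measure of this change. Only the flat steps above can guide the expectation, so no step beyond the scatter is expected in this assay, though with wide uncertainty.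

The estimated step reads a 1.2-fold lower number from compound 3 to compound 4 (0.07 log units; within the scatter). Compound 4 is expected at 170000 nM, with an estimated range of 60000 nM to 300000 nM.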

Compound 4, solubility: 195000 nM
Compound 4: the middle estimate sits 1.1-fold (0.06 log units) below what was measured, and the stated range covers the measured number.
By their numbers in this assay, from the lowest: compounds 2, 4, 1 and 3 (each within the scatter of the next).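

In this assay the change on the aromatic ring gives a 1.0-fold lower number from compound 3 to compound 4 (0.01 log units; within the scatter) and so stays within the scatter, as the three steps on the saturated ring carbon did. An aromatic carbon of the six-membered ring therefore joins that saturated ring carbon as a place where a change has left the read-out flat, here with the (4-methylpiperazin-1-yl)methyl group held constant and with trifluoromethoxy, of 5 heavy atoms and no hydrogen-bond donor, giving way to carboxy, of 3 heavy atoms and 1 hydrogen-bond donor. No measurement in hand accounts for this flat step.

As far as these compounds go, whether carboxy reads the same alongside the amino group of compound 1 or the dimethylamino group of compound 2 remains open. So does the reading for a primary amide or a methyl ester on the same aromatic carbon.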